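The source may report more compounds than this note shows. Statements on the series, on what has been measured and on what is new or still open speak of the compounds shown alone.

Measured in a functional assay on MV4-11 cells (Homo sapiens) for inhibition, read by resazurin assay, with a stated time of 72 h; a higher number here means a weaker inhibitor of growth, a lower number a stronger inhibitor of growth:

- compound 1, `COc1ccc(N(C)c2nccc(-c3cn(C)c4ccccc34)n2)c(OC)c1`: 2000 nM
- compound 2, `COc1ccc(Nc2nccc(-c3sc(SCc4cccnc4)nc3C)n2)c(OC)c1`: 270 nM
- compound 3, `COc1ccc(Nc2nccc(-c3c[nH]c4ccccc34)n2)c(OC(F)F)c1`: 4770 nM

Compound 2 gives the lowest number of the three in this assay; its distance to compound 1 and to compound 3 lies beyond the scatter in both cases, so it is the strongest growth inhibitor of this set. Compound 1 and compound 3 carry the shared core with a different ring system at the same position, and neither reaches the level of compound 2.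

Compound 4, `COc1ccc(Nc2nccc(-c3sc(OC(C)C)nc3C)n2)c(OC)c1`, keeps the core of compound 2 and changes the five-membered aromatic ring with 1 nitrogen and 1 sulfur at one aromatic carbon: isopropoxy in place of ((pyridin-3-yl)methyl)sulfanyl on an aromatic carbon. Among the measured compounds shown here, no measured pair in this set shows this kind of change, so the size of the step is open. A moderate rise in the number is expected, that is a somewhat weaker inhibitor than compound 2, with a step of a 2.6-fold higher number from compound 2 to compound 4 (0.41 log units; beyond the scatter) that may lie just beyond the scatter. Compound 4 is therefore estimated at 700 nM in this assay, within a range of 250 nM to 2500 nM.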

Compound 4, concentration for 50% growth inhibition: 8690 nM
Estimate against measurement, compound 4: 12-fold (1.09 log units) below; the whole stated range lies below it.
By their numbers in this assay, from the lowest: compound 2; then compound 1; then compounds 3 and 4 (each within the scatter of the next).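

In this assay, among the compounds shown here, the change to isopropoxy in place of ((pyridin-3-yl)methyl)sulfanyl gives a 32-fold higher number from compound 2 to compound 4 (1.51 log units; beyond the scatter) and so shows that the group on this aromatic carbon strongly affects growth inhibition, which the earlier compounds, with no one-place pair among them, could not show. The six-membered aromatic ring, its nitrogen and the sulfur all leave in this one change, so the step cannot be assigned to any one of them. No available measurement bears on the reason for the rise.

Open, going by these compounds, is which of these parts matters: a benzylsulfanyl group would test the ring nitrogen, a (pyridin-3-yl)methoxy group the sulfur, and a plain methylsulfanyl group the ring itself. Also open, on these data alone, is how an amine on this carbon would compare with both groups.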